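From compound 3 to compound 4: losing a methoxy group

The source may hold more compounds than are shown below. What is called first, only, known or untested is meant among the compounds shown, and "the series" means these compounds.

Of the compounds shown here, three have been measured so far. Compound 1 `Nc1ncnc2c1ncn2[C@H]1C=C[C@@H](CO)O1` reads < 0.01 h in an ADME assay for metabolic stability, at pH 1.5 (a lower number here means that the compound disappears faster, a higher number that the compound lasts longer), and that reading is a limit of the assay, not a number. Compound 2 `Cc1cccc2c1OP(=O)(OCC1CCC(n3cnc4c(O)ncnc43)O1)OC2` has a half-life of 0.2 h in this assay while compound 3 `COc1ccc2c(c1)COP(=O)(OCC1CCC(n3cnc4c(N)ncnc43)O1)O2` reaches 0.8 h as the higher of the two actual numbers. That gap lies beyond the usual scatter of repeated measurements, but these two compounds differ in more than one place, so it cannot be pinned on any single group.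

Compound 4 `Nc1ncnc2c1ncn2C1CCC(COP2(=O)OCc3ccccc3O2)O1` has not been measured yet. It differs from compound 3 in one place hydrogen in place of methoxy on an aromatic carbon with hydrogen in place of methoxy on an aromatic carbon, and the rest of the structure stays the same. Within the data shown here, no measured pair shows this change on its own, so the expectation starts from compound 3 at 0.8 h and allows for only a small shift. The expected step is a 1.1-fold lower number from compound 3 to compound 4 (0.06 log units; within the scatter) and this estimated shift does not go beyond the usual scatter. In this assay the estimated half-life for compound 4 is 0.7 h with a range from 0.35 h to 1.4 h for repeat measurements.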

Compound 4, half-life: 0.6 h
The estimate for compound 4 lay 1.2-fold (0.07 log units) above the measured number; the measured number falls inside the stated range.
By their numbers in this assay, from the lowest: compound 2; then compounds 4 and 3 (each within the scatter of the next). At a limit, below all of these: compound 1.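

In this assay, among these compounds, putting hydrogen in place of methoxy on an aromatic carbon gives a 1.3-fold lower number from compound 3 to compound 4 (0.12 log units; within the scatter), and this is the first pair of compounds here that differ in only one place. Among the compounds shown here, it therefore offers the first direct look at this position, and in this read-out the methoxy group and hydrogen cannot be told apart there, as the two compounds stay within the normal spread of repeated measurements. For the compounds shown here, nothing measured so far explains why the half-lives of this pair sit where they do, and no available evidence bears on this step.

From the compounds shown here alone, whether a different group on this same aromatic carbon, such as a chlorine atom, an amine or a carboxylic acid, would shift the half-life by more than the scatter remains open. Also open, going by these compounds, is whether hydrogen in place of methoxy would read the same way with changes elsewhere in the structure, as this conclusion rests on a single pair sharing everything else.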